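Swapping a nitrile chain for a hydroxymethyl arm

The source may hold more compounds than are shown below. What is called first, only, known or untested is meant among the compounds shown, and "the series" means these compounds.

Measured so far:
Compound 1 `Cc1cn2cccc(OCc3ccccc3)c2n1` gives 62%.
Compound 2 `Cc1nc2c(OCc3ccccc3)cccn2c1CCC#N` gives 40%.

Going by the values given here, in a functional assay on the whole organism with Rattus norvegicus as the target, with a stated time of 4 h, at a dose of 40 mg/kg by the intraperitoneal route (on this read-out lower numbers stand for less inhibition and higher numbers for more inhibition at the one dose given (going by the name of the read-out)), compound 2 stands lowest of the two measured numbers, and the only measured step, a number 22 percentage points lower from compound 1 to compound 2 (beyond the scatter), runs in that direction. Compound 3 `Cc1nc2c(OCc3ccccc3)cccn2c1CO` differs from compound 2 by hydroxy in place of cyanomethyl on a saturated chain carbon bound to an aromatic carbon. Among the compounds with values here, no measured step exchanges one group for another on this chain, so nothing bears directly on the change. The estimate for compound 3 therefore stays near compound 2 and is 45%, between 25% and 65%. That expected step is a number 5 percentage points higher from compound 2 to compound 3 (within the scatter).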

Compound 3, a percentage reported as inhibition, in the whole organism at one dose (the size of the read-out at that dose, not a potency): 99%
Estimate against measurement, compound 3: 54 percentage points below; measured number above the stated range.
By their numbers in this assay, from the lowest: compound 2; then compound 1; then compound 3.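

In this assay, the aromatic carbon that carried 2-cyanoethyl can also take a group that raises the number: hydroxymethyl there gives a number 37 percentage points higher from compound 1 to compound 3 (beyond the scatter). Exchanging one chain for the other gives a number 59 percentage points higher from compound 2 to compound 3 (beyond the scatter), so a chain at this carbon does not by itself lower the number; the outcome differs with the group. Nothing measured here accounts for this difference. As far as these compounds go, whether the hydroxy group or the short chain matters more stays open: methoxymethyl, aminomethyl or a longer 2-hydroxyethyl chain would help separate the two.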